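Methoxy for Fluoro on a Shared Core, Outcome Unknown

A few compounds are considered here, and "the series" means these few. Any claim that something is new, unique, unknown or untested is made for them only; others in the source may bear on it.

Compound 2 `Nc1cc(N)c2nc(-c3ccccc3)c(NCc3ccc(F)cc3)nc2c1` carries a 4-fluorobenzyl group on the shared core. In a functional assay on UO-31 cells (Homo sapiens) for inhibition, read by sulforhodamine B assay, with a stated time of 48 h (on this read-out lower numbers stand for stronger inhibition of growth and higher numbers for weaker inhibition of growth), compound 2 gives < 100000 nM, and this is a limit of the assay, not a number. Within the data shown here, its one measured neighbour is compound 1 `Nc1cc(N)c2nc(-c3ccccc3)c(NCc3ccc(Cl)c(Cl)c3)nc2c1`, which bears a 3,4-dichlorobenzyl group in the same position. In this assay compound 1 gives < 100000 nM, again a limit rather than a number. The step that the two limits leave unreadable from compound 1 to compound 2 can therefore be read neither in size nor in direction. Compound 3 `COc1ccc(CNc2nc3cc(N)cc(N)c3nc2-c2ccccc2)cc1` differs from compound 2 by methoxy in place of fluoro on an aromatic carbon. Among the measured compounds shown here, the only measured step that touches this part of the molecule is a step that the two limits leave unreadable from compound 1 to compound 2, and it sets no size to lean on; what the two measured values have in common is the limit of < 100000 nM in this assay, at which 2 of the 2 values shown sit. No direction beyond the scatter can be foreseen on that basis. Compound 3 is expected to give 40000 nM in this assay, with a range from 8000 nM to 100000 nM. That estimate means a step that the limit leaves unreadable from compound 2 to compound 3 is expected, and a further limit rather than a number remains quite likely.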

Compound 3, concentration for total growth inhibition: 28800 nM
The estimate for compound 3 lay 1.4-fold (0.14 log units) above the measured number, and the stated range covers the measured number.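

In this assay compound 3 gives 28800 nM.

No new step can be read from compound 3 to compound 1 or compound 2, because each of those two stands only as a limit: the limit of < 100000 nM in this assay, at which 2 of the 3 values shown sit.

The compounds shown leave open whether, and in which direction, methoxy, fluoro or the two chloro groups change growth inhibition on the shared core.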